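This account rests on a few compounds, and the source may have more. Where it says the series, first, only, none or still open, it means among the compounds named here.

Working notes on a series sharing the core of compound 1 `COc1ccc(C(=O)/C=C/c2ccc3ccccc3c2)c2c1C=CC(C)(C)O2`. In a functional assay on HCT-116 cells (Homo sapiens) for antiproliferative activity, read by MTT assay, with a stated time of 24 h (on this read-out higher numbers stand for weaker inhibition and lower numbers for stronger inhibition), compound 1 gives 5820 nM, and compound 2 `COc1ccc(C(=O)/C=C/c2cccc(C(F)(F)F)c2)c2c1C=CC(C)(C)O2` gives 9710 nM; these two numbers lie within the usual scatter of each other, so neither stands apart. Compound 3 `COc1ccc(C(=O)/C=C/c2cccc(O)c2)c2c1C=CC(C)(C)O2` has not yet been run. Relative to compound 2 it shows (hydroxy in place of trifluoromethyl on an aromatic carbon). Among the measured compounds shown here, no measured pair tracks this change, so only a step of about a 1.4-fold lower number from compound 2 to compound 3 (0.14 log units; within the scatter) is expected, in no direction beyond the scatter. Compound 3 is estimated at 7000 nM, with a range of 2500 nM to 20000 nM.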

Compound 3, half-maximal inhibitory concentration: > 10000 nM
Compound 3: no number, only a limit; the forecaster's own chance of this, stated with the estimate: 10%; middle value at least 1.4-fold (0.15 log units) from the limit.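

In this assay compound 3 gives only a limit, > 10000 nM, and not a number. Hydroxy in place of trifluoromethyl on this aromatic carbon gives an at least 1.0-fold higher number from compound 2 to compound 3 (0.01 log units; that floor lies within the scatter), so the change shows no move towards stronger inhibition, while its full size cannot be read: the limit of > 10000 nM in this assay, at which 1 of the 3 values shown sits.

As far as these compounds go, whether the step from compound 2 reaches beyond the scatter stays open. Also open, from the compounds shown here alone, is whether an amine or a carboxylic acid on the same aromatic carbon would give a readable number in this assay.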